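Capping the carboxy group of compound 3 with hexyl

The source may report more compounds than this note shows. Statements on the series, on what has been measured and on what is new or still open speak of the compounds shown alone.

Compound 3 `CCOc1ccc(-c2cccc(C(=O)O)c2)cc1` gives 23% in an assay on COS-7 cells for inhibition of patatin-like phospholipase domain-containing protein 2 (Mus musculus), tested at 200 uM (a lower number here means less inhibition, a higher number more inhibition at the concentration tested (going by the name of the read-out)), the lowest of the three numbers measured. Compound 2 `CCOc1ccc(-c2cccc(S(=O)(=O)NC)c2)cc1` gives 47% and compound 1 `CCOc1ccc(-c2cccc(S(=O)(=O)N(C)C)c2)cc1` gives 63%; the steps into the acid are a number 24 percentage points lower from compound 2 to compound 3 (beyond the scatter) and a number 40 percentage points lower from compound 1 to compound 3 (beyond the scatter), while a number 16 percentage points lower from compound 1 to compound 2 (beyond the scatter) is smaller. Compound 4 `CCCCCCOC(=O)c1cccc(-c2ccc(OCC)cc2)c1` differs from compound 3 by hexyl in place of hydrogen on an oxygen next to a carbonyl group, so the hydroxy becomes hexyloxy. Within the data shown here, no measured step alters the carboxy group itself; the two steps into compound 3 show only that the carboxy gives the lowest number, with both sulfonamides of compound 1 and compound 2 standing higher. Among the measured compounds shown here, a step back upward beyond the scatter is therefore expected, read as a number 22 percentage points higher from compound 3 to compound 4 (beyond the scatter), though no direct analogue supports it. Compound 4 is estimated at 45%, with a range from 20% to 70%.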

Compound 4, a percentage reported as inhibition, at one concentration (the size of the read-out at that concentration, not a potency): 48%
Compound 4: the middle estimate sits 3 percentage points below what was measured, and the stated range covers the measured number.
By their numbers in this assay, from the lowest: compound 3; then compounds 2 and 4 (each within the scatter of the next); then compound 1.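

Hexyl in place of hydrogen on an oxygen next to a carbonyl group is the first change to the carboxy group itself, and in this assay it gives a number 25 percentage points higher from compound 3 to compound 4 (beyond the scatter). The read-out at this position therefore does not depend on keeping the hydroxy of compound 3. Nothing available explains the rise. Going by these compounds, whether the rise needs the full hexyl chain stays open, and a methyl or octyl group on the same oxygen would test this. An amine in place of the hexyloxy is also untested here.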